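Acetyl to 4-nitrobenzoyl on the shared benzothiazole amide series

This account rests on a few compounds, and the source may have more. Where it says the series, first, only, none or still open, it means among the compounds named here.

Measured so far:
compound 1 `O=C(CSc1nc2ccc(NC(=O)c3ccc(Cl)cc3)cc2s1)NCc1ccc(Cl)cc1` — 29300 nM
compound 2 `CC(=O)Nc1ccc2nc(SCC(=O)NCc3ccc(Cl)cc3)sc2c1` — 10200 nM

The account concerns two compounds that share one core and differ only in the group on a carbonyl carbon whose other neighbour is an amide-type nitrogen. In a functional assay on MCF7 cells (Homo sapiens) for cytotoxicity, read by MTT assay, with a stated time of 48 h (a lower number here means a stronger inhibitor, a higher number a weaker inhibitor), compound 1 gives 29300 nM, and compound 2 gives 10200 nM. Among the compounds with values here, the single step between them, a 2.9-fold lower number from compound 1 to compound 2 (0.46 log units; beyond the scatter), makes compound 2 the lower of the two numbers.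

Compound 3 `O=C(CSc1nc2ccc(NC(=O)c3ccc([N+](=O)[O-])cc3)cc2s1)NCc1ccc(Cl)cc1` has not been measured. Against compound 2 the change is 4-nitrophenyl in place of methyl on a carbonyl carbon; cut one bond further out it reads acetyl to (4-nitrophenyl)carbonyl.

Within the data shown here, only one measured step bears on this: it replaced a methyl with an aryl group at the same carbonyl, and the aryl compound was the weaker one, as a 2.9-fold lower number from compound 1 to compound 2 (0.46 log units; beyond the scatter) shows. Compound 3 carries an aryl group at that position again, so a move back toward a higher number, of roughly the size seen between compound 1 and compound 2, is expected. Compound 3 is therefore estimated at 25000 nM, between 9000 nM and 70000 nM, which would be a step of a 2.5-fold higher number from compound 2 to compound 3 (0.39 log units; beyond the scatter).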

Compound 3, half-maximal inhibitory concentration: > 100000 nM
Compound 3 gave a limit, no number; the forecaster's own chance of this, stated with the estimate: 10%; middle value at least 4.0-fold (0.60 log units) away from the limit.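

In this assay compound 3 reads as a limit of the assay and not as a number: the limit of > 100000 nM in this assay, at which 1 of the 3 values shown sits. Within the data shown here, the earlier pair showed only that one aryl group on this carbonyl carbon, 4-chlorophenyl, gave a higher number than methyl, whereas replacing methyl with 4-nitrophenyl at the same place now gives an at least 9.8-fold higher number from compound 2 to compound 3 (0.99 log units; beyond the scatter), so a second aryl group moves the number in the same direction. Among these compounds, the group on the aryl ring also counts, which the earlier compounds could not show: nitro in place of chloro on an aromatic carbon gives an at least 3.4-fold higher number from compound 1 to compound 3 (0.53 log units; beyond the scatter), and the two aryl compounds therefore do not behave as one.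

As far as these compounds go, the limit leaves the full size of both new steps unknown, and it remains open whether an amine on that aromatic carbon would bring the number back toward that of compound 1. From the compounds shown here alone, it is equally open whether a longer alkyl chain on the carbonyl carbon, carrying no ring, would stay near compound 2 or move toward the aryl compounds.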